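Swapping a trifluoromethyl phenyl for a methylphenyl on a piperazine

A few compounds are considered here, and "the series" means these few. Any claim that something is new, unique, unknown or untested is made for them only; others in the source may bear on it.

Measured so far:
- compound 1, `CCCc1nc(-c2ccccc2)c(CNCCCN2CCN(c3cccc(C(F)(F)F)c3)CC2)o1`: 650 nM
- compound 2, `CCCc1nc(-c2ccccc2)c(CNCCN2CCN(C(c3ccccc3)c3ccccc3)CC2)o1`: 7470 nM
- compound 3, `CCCc1nc(-c2ccccc2)c(CNCCN2CCN(c3cccc(C)c3C)CC2)o1`: 1710 nM

All three were tested in an assay on HEK293 cells for inhibition of Voltage-dependent T-type calcium channel subunit alpha-1G (Homo sapiens), read by patch clamp; a lower number here means a stronger inhibitor, a higher number a weaker inhibitor. Compound 1 gives the lowest number of the three in this assay, so it is the strongest inhibitor of this small set. Compound 3 lies closest to it, yet its number is still beyond the scatter of the measurement, and compound 2 stands furthest away. Compound 2 and compound 3 both differ from compound 1 in more than one place, so no single structural step can be read from their values.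

Compound 4, `CCCc1nc(-c2ccccc2)c(CNCCCN2CCN(c3ccccc3C)CC2)o1`, is not yet measured. It keeps everything in compound 1 except one group: 2-methylphenyl in place of 3-(trifluoromethyl)phenyl on an amine nitrogen in a ring. Without a measured pair that isolates this exchange, the direction can only be guessed from what the set shows: every change away from the aryl group of compound 1 seen so far has given a higher number. A modest weakening, beyond the scatter, is therefore expected for the step of a 2.0-fold higher number from compound 1 to compound 4 (0.30 log units; within the scatter) in this assay. Compound 4 is estimated at 1300 nM, with a likely range from 500 nM to 3500 nM.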

Compound 4, half-maximal inhibitory concentration: 8750 nM
Compound 4: the middle estimate sits 6.7-fold (0.83 log units) below what was measured; measured number above the stated range.
By their numbers in this assay, from the lowest: compound 1; then compound 3; then compounds 2 and 4 (each within the scatter of the next).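

Among these compounds, this is the first pair in the set that differs in only one place, so in this assay the aryl group on an amine nitrogen in a ring can now be read on its own: 2-methylphenyl in place of 3-(trifluoromethyl)phenyl gives a 13-fold higher number from compound 1 to compound 4 (1.13 log units; beyond the scatter) and this large step lies beyond the scatter. The position is clearly sensitive to this exchange, even though both groups carry one six-membered aromatic ring of carbon only, no hydrogen-bond donors or acceptors and no net charge. Nothing measured here explains why the number rises so far.

The exchange alters both the group on the phenyl ring and where that group sits, so a 3-methylphenyl or a 2-(trifluoromethyl)phenyl group would be needed to tell these two changes apart. From the compounds shown here alone, it also remains open whether the same exchange would have a step of similar size on a longer chain, or whether a plain phenyl group would fall closer to compound 1 or to compound 4.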